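The compounds below may be only part of what the source reports. "The series", "measured", "known", "first", "only" and "open" are said of these compounds alone.

Three small compounds have been tested in an assay on isolated protein for inhibition of protein kinase C zeta type (Homo sapiens), with stated times of 1 h and 2.5 min, tested at 30 uM; a lower number here means less inhibition, a higher number more inhibition at the concentration tested (going by the name of the read-out). Compound 1 `CCOC(=O)c1c(-c2cccc(F)c2)csc1N` gives 38%, compound 2 `CCOC(=O)c1c(-c2cccc(C#N)c2)csc1N` gives 32%, and compound 3 `Nc1scc(-c2cccc(F)c2)c1C(=O)OCc1ccccc1` gives 53%. Compound 2 differs from compound 1 only by cyano in place of fluoro on an aromatic carbon, a change that made a step of a number 6 percentage points lower from compound 1 to compound 2 (within the scatter). Compound 3 differs from compound 1 in its core by phenyl in place of methyl on a saturated chain carbon bound to an oxygen next to a carbonyl group, which brought a number 15 percentage points higher from compound 1 to compound 3 (beyond the scatter) and leaves compound 3 with the highest number of the three. Compound 4 `N#Cc1cccc(-c2csc(N)c2C(=O)OCc2ccccc2)c1` carries the change (cyano in place of fluoro on an aromatic carbon), the same change already seen between compound 1 and compound 2, now set on the core of compound 3. Compound 4 is expected to show a step of a number 6 percentage points lower from compound 3 to compound 4 (within the scatter), because the same change earlier gave a number 6 percentage points lower from compound 1 to compound 2 (within the scatter). Compound 4 is therefore estimated at 47%, with a likely range from 32% to 62%.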

Compound 4, a percentage reported as inhibition, at one concentration (the size of the read-out at that concentration, not a potency): 25%
Compound 4: the middle estimate sits 22 percentage points above what was measured; measured number below the stated range.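

In this assay, cyano in place of fluoro did not carry over by the same amount from one core to the other: the same change on two cores in this assay, a number 6 percentage points lower (within the scatter) from compound 1 to compound 2 and a number 28 percentage points lower (beyond the scatter) from compound 3 to compound 4, 22 percentage points apart, beyond the scatter of two such steps. On the core of compound 3, this change gave a number 28 percentage points lower from compound 3 to compound 4 (beyond the scatter), and with cyano present, phenyl in place of methyl gave a number 7 percentage points lower from compound 2 to compound 4 (within the scatter), so the two changes do not simply add up: the same change on two cores in this assay, a number 15 percentage points higher (beyond the scatter) from compound 1 to compound 3 and a number 7 percentage points lower (within the scatter) from compound 2 to compound 4, 22 percentage points apart, beyond the scatter of two such steps. These four compounds show that the result of each change depended on the other in this small set, but they do not show why, or whether this would hold for other groups.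

As far as these compounds go, it remains open how an amine or a chloro group on that aromatic carbon would behave on either core. A longer chain in place of methyl is also untested here, so it is unclear how it would compare with phenyl alongside fluoro or cyano.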